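The source may hold more compounds than are shown below. What is called first, only, known or untested is meant among the compounds shown, and "the series" means these compounds.

Working notes on the series in a functional assay on A549 cells (Homo sapiens) for antiproliferative activity, read by MTT assay, with a stated time of 48 h; on this read-out lower numbers stand for stronger inhibition and higher numbers for weaker inhibition: compound 1 (`COc1ccc(N(C)c2ccnc(Cl)n2)cc1Cl`) gives 621 nM, compound 2 (`COc1ccc(N(C)c2ccnc(Cl)n2)cc1[N+](=O)[O-]`) gives 3780 nM and compound 3 (`COc1ccc(N(C)c2ccnc(Cl)n2)cc1OCCBr`) gives 4640 nM. Compound 3 stands at the high end of these numbers, level with compound 2: a 1.2-fold higher number from compound 2 to compound 3 (0.09 log units; within the scatter). Both lie clear of compound 1: a 6.1-fold higher number from compound 1 to compound 2 (0.78 log units; beyond the scatter) and a 7.5-fold higher number from compound 1 to compound 3 (0.87 log units; beyond the scatter). Compound 4 (`COc1ccc(N(C)c2ccnc(Cl)n2)cc1OCCCBr`) extends the chain, 2-bromoethoxy to 3-bromopropoxy: bromomethyl in place of bromo on a saturated chain carbon, two bonds along the chain from an oxygen on an aromatic ring. Within the data shown here, no measured step changes chain length. Among the measured compounds shown here, the modest steps replace chloro outright, and the one exchange between larger groups, a 1.2-fold higher number from compound 2 to compound 3 (0.09 log units; within the scatter), stays within the scatter. The expected change is therefore none beyond the scatter, a 1.0-fold lower number from compound 3 to compound 4 (0.01 log units; within the scatter). In this assay the estimate for compound 4 is 4500 nM, with an expected range of 1800 nM to 11000 nM.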

Compound 4, half-maximal inhibitory concentration: 862 nM
Estimate against measurement, compound 4: 5.2-fold (0.72 log units) above, and the stated range ends above it.
By their numbers in this assay, from the lowest: compounds 1 and 4 (each within the scatter of the next); then compounds 2 and 3 (each within the scatter of the next).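

Among these compounds, the 3-bromopropoxy chain does not behave like 2-bromoethoxy in this assay: a 5.4-fold lower number from compound 3 to compound 4 (0.73 log units; beyond the scatter), so chain length at this position can move the read-out, which no earlier step could show. The same chain also separates from nitro, a 4.4-fold lower number from compound 2 to compound 4 (0.64 log units; beyond the scatter), yet it stays level with chloro, a 1.4-fold higher number from compound 1 to compound 4 (0.14 log units; within the scatter), so a larger group here is compatible with the values of compound 1. Nothing at hand accounts for this shift.

Among the compounds shown here, with only two chain lengths, it remains open whether a longer chain such as 4-bromobutoxy continues the trend. On these data alone, it is equally open whether the bromine is needed, which a chain ending in a hydroxyl or an amine would address.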